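Swapping 3-Methylphenyl for 4-Bromophenyl on the Shared Core

A few compounds are considered here, and "the series" means these few. Any claim that something is new, unique, unknown or untested is made for them only; others in the source may bear on it.

Three measured compounds share one core and differ only in the aromatic group attached to it. Compound 1 `Cn1nc(-c2nnc(-c3ccc(O)cc3)o2)c2ccccc21` carries a 4-hydroxyphenyl group, compound 2 `Cn1nc(-c2nnc(-c3ccccc3Br)o2)c2ccccc21` a 2-bromophenyl group, and compound 3 `Cc1cccc(-c2nnc(-c3nn(C)c4ccccc34)o2)c1` a 3-methylphenyl group. In an ADME assay on L02 cells (Homo sapiens) for cytotoxicity, read by MTT assay, with a stated time of 72 h (on this read-out higher numbers stand for weaker inhibition and lower numbers for stronger inhibition), compound 1 reaches only a limit of > 100000 nM, not a number. Compound 2 gives 89000 nM in this assay. In this assay compound 3 likewise shows only a limit of > 100000 nM, a position shared as described by the limit of > 100000 nM in this assay, at which 2 of the 3 values shown sit. So compound 3 stands at the edge of what the assay can report. Compound 4 `Cn1nc(-c2nnc(-c3ccc(Br)cc3)o2)c2ccccc21` has not been measured; its change is 4-bromophenyl in place of 3-methylphenyl on an aromatic carbon. Within the data shown here, two measured steps bear on it: an at least 1.1-fold higher number from compound 2 to compound 3 (0.05 log units; that floor lies within the scatter), and an at least 1.1-fold lower number from compound 1 to compound 2 (0.05 log units; that floor lies within the scatter), both within the scatter, while a step that the two limits leave unreadable from compound 1 to compound 3. Since every step shown is small or unreadable, no step beyond the scatter is expected, namely an at least 1.0-fold lower number from compound 3 to compound 4 (0.02 log units; that floor lies within the scatter). Compound 4 is therefore estimated at 95000 nM, within a range from 45000 nM to 200000 nM, with a fair chance that only a limit is reported.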

Compound 4, half-maximal inhibitory concentration: > 100000 nM
Compound 4: no number, only a limit (the forecaster's own chance of this, stated with the estimate: 55%); middle value at least 1.0-fold (0.02 log units) away from the limit.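

Among these compounds, putting 4-bromophenyl in place of 2-bromophenyl gives an at least 1.1-fold higher number from compound 2 to compound 4 (0.05 log units; that floor lies within the scatter) in this assay, so this change of the bromine-bearing group shows no step that can be told apart from the scatter. The steps to compound 4 from compound 1 and from compound 3 join two limits and cannot be read. Compound 4 gives only a limit, so the 4-bromophenyl group joins the 4-hydroxyphenyl and 3-methylphenyl groups at the same edge of the read-out: the limit of > 100000 nM in this assay, at which 3 of the 4 values shown sit.

On these data alone, how far compound 1, compound 3 and compound 4 truly lie from one another remains unknown, as does whether any change at this place can move the number beyond the scatter. Every group shown is a substituted phenyl, so an amine, a carboxylic acid or a longer chain on this aromatic carbon remains an open case.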